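The source may report more compounds than this note shows. Statements on the series, on what has been measured and on what is new or still open speak of the compounds shown alone.

Compound 1 `Cc1cc(CCCOc2c(C)cc(-c3noc(C)n3)cc2C)on1` gives 0.45 h in an in vitro ADME assay on microsomes from liver (Simiiformes); a higher number here means that the compound lasts longer, a lower number that the compound disappears faster. Compound 3 `Cc1cc(CCCOc2c(C)cc(-c3noc(CC(F)(F)F)n3)cc2C)on1` gives 0.533 h, so these two numbers lie within the scatter of each other and compound 1 shares the short end of the series with it. Compound 2 `CCc1cc(CCCOc2c(C)cc(-c3noc(C(F)(F)F)n3)cc2C)on1` stands at > 2.5 h, which is a limit of the assay and not a number.

Compound 4 `COCc1cc(CCCOc2c(C)cc(-c3noc(C)n3)cc2C)on1` changes compound 1 by methoxy in place of hydrogen on a saturated chain carbon bound to an aromatic carbon, which turns methyl into methoxymethyl. For the measured compounds named here, only one measured step bears on this kind of change, and there a different group, trifluoromethyl, enters at the same kind of carbon. That step is a 1.2-fold higher number from compound 1 to compound 3 (0.07 log units; within the scatter). It shows that one such replacement left the half-life in this assay within the scatter, although a single step with another group is thin support. No step beyond the scatter is therefore expected, in either direction, and the estimated change is a 1.1-fold lower number from compound 1 to compound 4 (0.05 log units; within the scatter). For compound 4 the expected half-life is 0.4 h, with an estimated range from 0.2 h to 0.8 h.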

Compound 4, half-life: 0.5 h
Estimate against measurement, compound 4: 1.3-fold (0.10 log units) below; the measured number falls inside the stated range.
By their numbers in this assay, from the lowest: compounds 1, 4 and 3 (each within the scatter of the next). At a limit, above all of these: compound 2.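

In this assay, for the compounds shown here, the change from 3-methyl-1,2-oxazol-5-yl to 3-(methoxymethyl)-1,2-oxazol-5-yl gives a 1.1-fold higher number from compound 1 to compound 4 (0.05 log units; within the scatter), the first measured step at this group of the molecule. The earlier step, a 1.2-fold higher number from compound 1 to compound 3 (0.07 log units; within the scatter), replaced a hydrogen on the same kind of carbon but elsewhere in the molecule, so it could only suggest what this site would do; now a direct reading shows that methoxy in place of hydrogen here leaves the half-life within the scatter, and both steps shown on this kind of carbon stay within it. The compounds shown give no measured ground for why the half-life holds at this site.

Whether this carbon tolerates other groups just as well stays open, since an amine, a carboxylic acid or a longer chain such as ethoxymethyl could behave differently from methoxy, and the step shown covers only this one replacement on this one core. Compound 2 stands at > 2.5 h, a limit and not a number, and no step connects it to any other compound shown, so what separates it from the rest also remains unresolved.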